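This account rests on a few compounds, and the source may have more. Where it says the series, first, only, none or still open, it means among the compounds named here.

Three compounds share one core and differ only in the group attached to the sulfonamide nitrogen on the outer benzene ring. Compound 1 `CC[C@@H]1C(=O)N(C)c2cnc(Nc3ccc(S(=O)(=O)NCCO)cc3)nc2N1C1CCCC1` carries a 2-hydroxyethyl there, and in a functional assay on NCI-H1975 cells (Homo sapiens) for antiproliferative activity, read by CCK-8 assay, with a stated time of 72 h (a lower number here means a stronger inhibitor of growth, a higher number a weaker inhibitor of growth), compound 1 gives 2100 nM. Compound 2 `CC[C@@H]1C(=O)N(C)c2cnc(Nc3ccc(S(N)(=O)=O)cc3)nc2N1C1CCCC1` carries only hydrogen on that nitrogen, and compound 2 gives 5290 nM. Compound 3 `CCCCNS(=O)(=O)c1ccc(Nc2ncc3c(n2)N(C2CCCC2)[C@H](CC)C(=O)N3C)cc1` carries a butyl, and compound 3 gives 1610 nM, the lowest of the three numbers. Compound 3 sits nearest to compound 1, with a 1.3-fold lower number from compound 1 to compound 3 (0.12 log units; within the scatter), and furthest from compound 2, with a 3.3-fold lower number from compound 2 to compound 3 (0.52 log units; beyond the scatter).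

Compound 4 `CC[C@@H]1C(=O)N(C)c2cnc(Nc3ccc(S(=O)(=O)NCCCO)cc3)nc2N1C1CCCC1` has not yet been measured. It differs from compound 3 in one place: hydroxy in place of methyl on a saturated chain carbon, three bonds along the chain from a sulfonamide nitrogen. Among the measured compounds shown here, only one measured step bears on this change: the step of a 1.3-fold lower number from compound 1 to compound 3 (0.12 log units; within the scatter), in which ethyl replaced hydroxy two bonds along the chain from the sulfonamide nitrogen, stayed within the scatter. Putting a hydroxy back onto the end of the chain, one bond further out, is therefore expected to move the number little, if at all.

The estimate for compound 4 is accordingly a step of a 1.2-fold higher number from compound 3 to compound 4 (0.07 log units; within the scatter), within the scatter. Compound 4 is expected to give about 1900 nM, with a likely range from 900 nM to 4000 nM.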

Compound 4, concentration for 50% growth inhibition: 2140 nM
The estimate for compound 4 lay 1.1-fold (0.05 log units) below the measured number, within the range that was stated.
By their numbers in this assay, from the lowest: compounds 3, 1 and 4 (each within the scatter of the next); then compound 2.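

In this assay, replacing the methyl at the end of the butyl chain with hydroxy gives a 1.3-fold higher number from compound 3 to compound 4 (0.12 log units; within the scatter) and so shows that, at this chain end, a terminal hydroxy and a terminal methyl cannot be told apart. The earlier compounds shown here held only one hydroxy-bearing chain, and the comparison of 2-hydroxyethyl with 3-hydroxypropyl now adds a 1.0-fold higher number from compound 1 to compound 4 (0.01 log units; within the scatter) as a second step that stays within the scatter, so these chains also cannot be separated from each other. The clearer difference remains the one from the bare sulfonamide, where a 2.5-fold lower number from compound 2 to compound 4 (0.39 log units; beyond the scatter) joins the earlier steps from compound 2 in showing that all three substituted chains shown lie beyond the scatter from hydrogen on that nitrogen.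

As far as these compounds go, it remains open whether an amine or a carboxylic acid at the chain end, or a longer chain, would leave the number just as unchanged or shift it beyond the scatter. Nothing given here explains why hydrogen on the sulfonamide nitrogen differs from these chains or why the chains match one another.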